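This account rests on a few compounds, and the source may have more. Where it says the series, first, only, none or still open, it means among the compounds named here.

Measured so far in an ADME assay on Akata cells (Homo sapiens) for cytotoxicity, with a stated time of 7 days; a lower number here means that less compound is tolerated, a higher number that more compound is tolerated:
Compound 1, `Nc1nc(NC2CCCCC2)c2ncn(/C=C3/CC3(CO)CO)c2n1`, gives > 24000 nM, a limit of the assay rather than a number.
Compound 2, `CC(C)CSc1nc(N)nc2c1ncn2/C=C1/CC1(CO)CO`, gives > 20000 nM, also a limit.
Compound 3, `Nc1nc(NCc2ccccc2)c2ncn(/C=C3/CC3(CO)CO)c2n1`, gives > 24000 nM, again a limit.

Compound 2 therefore stands at a limit in this assay, as do the two others: one value sits at the limit of > 20000 nM in this assay, at which 1 of the 3 values shown sits, and two sit at the limit of > 24000 nM in this assay, at which 2 of the 3 values shown sit. Going by the values given here, none of the measured steps can be read. The change from compound 1 to compound 2 gives a step that the two limits leave unreadable from compound 1 to compound 2, from compound 1 to compound 3 gives a step that the two limits leave unreadable from compound 1 to compound 3, and from compound 2 to compound 3 gives a step that the two limits leave unreadable from compound 2 to compound 3. Every single-point change tried on the shared core has left the readout at a limit.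

Compound 4, `Nc1nc(SC2CCCC2)c2ncn(/C=C3/CC3(CO)CO)c2n1`, is the next point. Relative to compound 2 the change is cyclopentyl in place of isobutyl on a sulfur, sitting on a sulfur whose other neighbours are an aromatic carbon. Among the compounds with values here, no measured step bears on a cyclopentyl group here, and the three steps that do exist are all unreadable, so no step beyond the scatter is expected in this assay; the expected step is a step that the limit leaves unreadable from compound 2 to compound 4. Compound 4 is estimated at 24000 nM, in the range 10000 nM to 60000 nM, most likely reported as a limit once more.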

Compound 4, half-maximal cytotoxic concentration: > 20000 nM
Compound 4: a limit, no number (the forecaster's own chance of this, stated with the estimate: 85%); the middle value is on the limit's open side.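

In this assay compound 4 gives > 20000 nM, a limit, so the steps to compound 4 from compound 1, compound 2 and compound 3 cannot be read. The compounds shown leave open at what concentration any of them turns cytotoxic, and whether these changes on the shared core alter it.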